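The compounds below may be only part of what the source reports. "The series", "measured", "known", "first", "only" and "open" are said of these compounds alone.

Working notes on the series. For the measured compounds named here, in a physicochemical assay for solubility, read by HPLC, with a stated time of 24 h (a higher number here means a more soluble compound, a lower number a less soluble compound), compound 2 `CN(C)S(=O)(=O)NC[C@H]1CN(c2ccc(-n3cc(-c4ccccn4)cn3)c(F)c2)C(=O)O1` gives 472000 nM, the highest of the two numbers so far. Going by the values given here, its nearest neighbour is compound 1 `O=CNC[C@H]1CN(c2ccc(-n3cc(-c4ccccn4)cn3)c(F)c2)C(=O)O1`, which in this assay gives 217000 nM; the step of a 2.2-fold higher number from compound 1 to compound 2 (0.34 log units; beyond the scatter) is modest and is the only measured step in the set.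

Compound 3 `NC(=O)[C@H]1CN(c2ccc(-n3cc(-c4ccccn4)cn3)c(F)c2)C(=O)O1` is not yet measured. It differs from compound 2 by carbamoyl in place of ((dimethylsulfamoyl)amino)methyl on a saturated ring carbon. Among the compounds with values here, no measured step covers this exchange: the step from compound 1 to compound 2 concerns only the replacement of formyl by dimethylsulfamoyl on the amine nitrogen, that is, a change within the group that now leaves, while the carbamoyl that enters has no counterpart among the measured compounds. That step shows the dimethylsulfamoyl group going with the higher number, so its removal is taken to bring compound 3 back toward the level of compound 1 in this assay, a modest decrease at most, with the direction held loosely.

Compound 3 is therefore expected to give about 220000 nM in this assay, within 80000 nM to 600000 nM, which means an expected step of a 2.1-fold lower number from compound 2 to compound 3 (0.33 log units; beyond the scatter).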

Compound 3, solubility: 27200 nM
Estimate against measurement, compound 3: 8.1-fold (0.91 log units) above; the whole stated range lies above it.
By their numbers in this assay, from the lowest: compound 3; then compound 1; then compound 2.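

In this assay the saturated ring carbon next to the ring oxygen proves far more sensitive to exchange of the whole substituent than the earlier step at the amine nitrogen suggested: carbamoyl in place of ((dimethylsulfamoyl)amino)methyl gives a 17-fold lower number from compound 2 to compound 3 (1.24 log units; beyond the scatter), and carbamoyl in place of (formylamino)methyl gives an 8.0-fold lower number from compound 1 to compound 3 (0.90 log units; beyond the scatter). Both steps run the same way and are beyond the scatter, so among these compounds the number depends more on what is attached directly at this ring carbon than on which group caps the amine nitrogen, and compound 3, with the smallest substituent of the series, stands lowest. Nothing available bears on what lies behind these steps.

The compounds shown leave open whether the lower number goes with the shorter substituent or with the carbamoyl itself, a question that a plain aminomethyl or hydroxymethyl group at this carbon would bear on. A carboxylic acid, or an N,N-dimethylcarbamoyl group, at the same place would show how far the number depends on the amide hydrogens of the carbamoyl.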